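The compounds below may be only part of what the source reports. "The series", "measured", "known", "first", "only" and "open" are said of these compounds alone.

Measured compounds:
- compound 1 `NC(=O)C(CCn1ccnc1)(c1ccccc1)c1ccccc1`: 5.07 nM
- compound 2 `Cc1cn(CCC(C(N)=O)(c2ccccc2)c2ccccc2)cn1`: 10.1 nM

Both compounds were tested in an assay on ileum with muscarinic acetylcholine receptor M3 (Cavia porcellus) as the target; on this read-out lower numbers stand for stronger inhibition and higher numbers for weaker inhibition. Compound 1 gives 5.07 nM there, and compound 2 gives 10.1 nM. Within the data shown here, the only step between them, a 2.0-fold higher number from compound 1 to compound 2 (0.30 log units; within the scatter), is a change within the scatter, so the two numbers cannot be told apart. Among the measured compounds shown here, compound 2 holds the higher of the two numbers, with compound 1 as its sole neighbour.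

Compound 3 `NC(=O)C(CCn1cnc2ccccc21)(c1ccccc1)c1ccccc1` is not yet measured in this assay. It differs from compound 2 by 1H-benzimidazol-1-yl in place of 4-methyl-1H-imidazol-1-yl on a saturated chain carbon, three bonds along the chain from two aromatic carbons and a carbonyl carbon. For the measured compounds named here, no measured step concerns a fused ring of this kind; the one step that exists, from compound 1 to compound 2, only exchanges hydrogen for methyl on an aromatic carbon and stays within the scatter. That step therefore gives little guidance on the size of the present change, and no step beyond the scatter is expected in this assay, though the uncertainty is wider than for the methyl step. Compound 3 is accordingly expected to come out near compound 2, with an expected step of a 1.2-fold higher number from compound 2 to compound 3 (0.07 log units; within the scatter). The estimate for compound 3 is 12 nM, with a range from 4 nM to 36 nM.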

Compound 3, antagonist equilibrium constant: 2130 nM
Compound 3: the middle estimate sits 180-fold (2.25 log units) below what was measured, and the stated range ends below it.
By their numbers in this assay, from the lowest: compounds 1 and 2 (each within the scatter of the next); then compound 3.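

In this assay, placing 1H-benzimidazol-1-yl on the saturated chain carbon in place of 4-methyl-1H-imidazol-1-yl gives a 210-fold higher number from compound 2 to compound 3 (2.32 log units; beyond the scatter), and placing it there in place of 1H-imidazol-1-yl gives a 420-fold higher number from compound 1 to compound 3 (2.62 log units; beyond the scatter). The earlier compounds shown here showed only that methyl in place of hydrogen on an aromatic carbon leaves the number within the scatter, whereas this change shows that the read-out at this position is not indifferent to every change of the group: adding a six-membered aromatic ring of carbon only, with hydrogen-bond donor and acceptor counts and net charge unchanged, moves the number far beyond it. Nothing available bears on why the number rises so steeply.

The compounds shown leave open whether the rise follows from the fused ring itself or would also appear with an unfused phenyl group carried on the imidazole ring. They also leave open how a dimethylamino group or a piperidine ring, with no aromatic ring at this place, or a longer chain carrying the 1H-imidazol-1-yl group would read in this assay.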